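Aminohexyl in Place of Aminophenyl on the Ring Nitrogen

This account rests on a few compounds, and the source may have more. Where it says the series, first, only, none or still open, it means among the compounds named here.

Compound 1 `Nc1cccc(Nc2c(C(=O)NCc3ccc(F)cc3)nc(Br)c3cccnc23)c1`: 8000 nM
Compound 2 `COc1cccc(CNC(=O)c2nc(Br)c3cccnc3c2N[C@H]2CC[C@H](N)CC2)c1`: 7000 nM
Compound 3 `N[C@H]1CC[C@H](Nc2c(C(=O)NCc3ccccn3)nc(Br)c3cccnc23)CC1`: 4000 nM

In a functional assay on MDA-MB-435 cells (Homo sapiens) for cytotoxicity, read by MTT assay, with a stated time of 72 h (on this read-out higher numbers stand for weaker inhibition and lower numbers for stronger inhibition), compound 1 gives the highest of the three numbers, but compound 2 and compound 3 both lie within the scatter of it. Compound 4 `NCCCCCCNc1c(C(=O)NCc2ccc(F)cc2)nc(Br)c2cccnc12` differs from compound 1 by 6-aminohexyl in place of 3-aminophenyl on a nitrogen on an aromatic ring. Among the compounds with values here, the only measured step, a 1.8-fold lower number from compound 2 to compound 3 (0.24 log units; within the scatter), concerns a group on the amide-type nitrogen, not the ring nitrogen, so no step bears directly on this change. Compound 2, whose group on that ring nitrogen also holds no aromatic ring, gives 7000 nM, within the scatter of compound 1. Compound 4 is therefore expected to show no step beyond the scatter, no change at the digits printed from compound 1 to compound 4 (within the scatter). The estimate for compound 4 is 8000 nM, ranging from 3000 nM to 20000 nM.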

Compound 4, half-maximal inhibitory concentration: 6000 nM
Beside the measured number, compound 4's estimate is 1.3-fold (0.12 log units) above it; low and high end bracket the measured number.
By their numbers in this assay, from the lowest: compounds 3, 4, 2 and 1 (each within the scatter of the next).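

Within the data shown here, at the ring nitrogen, 6-aminohexyl in place of 3-aminophenyl gives a 1.3-fold lower number from compound 1 to compound 4 (0.12 log units; within the scatter) in this assay and is the first measured step at this position. With the same amide-type group held constant, an open chain without a ring and an aromatic ring of the same heavy-atom count give values within the scatter of each other. The compounds shown leave open whether a shorter chain, a longer chain or a carboxylic acid in place of the amine would move the number beyond the scatter. No measured evidence bears on this result.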